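A few compounds are considered here, and "the series" means these few. Any claim that something is new, unique, unknown or untested is made for them only; others in the source may bear on it.

In an assay on CHO cells for displacement of a labelled ligand from adenosine receptor A3 (Homo sapiens), read by scintillation counting, with a stated time of 60 min, tested at 1 uM (on this read-out higher numbers stand for more inhibition at the one concentration tested (going by the name of the read-out) and lower numbers for less inhibition), compound 1 `Nc1nc(Cc2ccccc2)nc2cn(-c3ccccc3O)nc12` gives 19%, compound 2 `Cc1nc(N)c2nn(Cc3ccccc3)cc2n1` gives 1%, and compound 3 `Nc1nc(Cc2ccccc2)nc2cn(Cc3ccccc3)nc12` gives 15%. Compound 3 sits second highest of the three: it lies within the scatter of compound 1, with a step of a number 4 percentage points lower from compound 1 to compound 3 (within the scatter), and beyond the scatter of compound 2, with a step of a number 14 percentage points higher from compound 2 to compound 3 (beyond the scatter). Compound 4 `Cn1cc2nc(Cc3ccccc3)nc(N)c2n1` differs from compound 3 by hydrogen in place of phenyl on a saturated chain carbon bound to an aromatic nitrogen. The step from compound 2 to compound 3 is the closer parallel, since it also adds or removes a phenyl, though at another place; the step from compound 1 to compound 3 shows that swapping the group on the aromatic nitrogen changed little. A modest fall is therefore expected in this assay, estimated at a number 8 percentage points lower from compound 3 to compound 4 (within the scatter), giving compound 4 an expected 7% within 0% to 18%.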

Compound 4, a percentage reported as inhibition, at one concentration (the size of the read-out at that concentration, not a potency): 1%
The estimate for compound 4 lay 6 percentage points above the measured number; the range from low to high includes it.
By their numbers in this assay, from the lowest: compounds 2 and 4 (each within the scatter of the next); then compounds 3 and 1 (each within the scatter of the next).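

At this aromatic nitrogen, methyl reads lower in this assay than either ring-bearing group, with a number 14 percentage points lower from compound 3 to compound 4 (beyond the scatter) and a number 18 percentage points lower from compound 1 to compound 4 (beyond the scatter). So the earlier swap of one ring-bearing group for the other left the number within the scatter, while losing the phenyl ring of benzyl moves it beyond the scatter. Nothing shown here explains this fall.

On these data alone, it remains open whether a longer chain such as propyl on this nitrogen would restore the number. The same holds for a benzyl ring carrying an amine or a carboxylic acid.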